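Phenyl for pyrrolidin-1-yl on the carbonyl of compound 3

The source may hold more compounds than are shown below. What is called first, only, known or untested is meant among the compounds shown, and "the series" means these compounds.

In an ADME assay on microsomes from liver (Mus musculus) for metabolic stability, read by mass spectrometry, using NADPH, tested at 1.5 uM (a lower number here means that the compound disappears faster, a higher number that the compound lasts longer), compound 3 `O=C(Nc1ccc2sc(-c3ccccc3)nc2c1)N1CCCC1` gives 0.3 h, compound 1 `O=C(Nc1ccc2sc(-c3ccccc3)nc2c1)N1CCCCC1` gives 0.283 h and compound 2 `O=C(Nc1ccc2sc(-c3ccc(F)c(F)c3)nc2c1)N1CCCC1` gives 0.233 h. These three numbers lie within the scatter of one another, so compound 3 stands level with the other two.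

Compound 4 `O=C(Nc1ccc2sc(-c3ccccc3)nc2c1)c1ccccc1` carries phenyl in place of pyrrolidin-1-yl on a carbonyl carbon. The nearest measured change, pyrrolidin-1-yl in place of piperidin-1-yl on a carbonyl carbon, gives a 1.1-fold higher number from compound 1 to compound 3 (0.03 log units; within the scatter). Phenyl in place of 3,4-difluorophenyl on an aromatic carbon gives a 1.3-fold higher number from compound 2 to compound 3 (0.11 log units; within the scatter). Among the measured compounds shown here, no measured step puts an aromatic ring in place of a non-aromatic one on the carbonyl carbon, so this evidence is only indirect. With both measured steps this small, no change beyond the scatter is expected in this assay. The estimated step is a 1.2-fold higher number from compound 3 to compound 4 (0.07 log units; within the scatter). For compound 4 the expected half-life is 0.35 h, with an estimated range of 0.15 h to 0.8 h.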

Compound 4, half-life: 0.833 h
The estimate for compound 4 lay 2.4-fold (0.38 log units) below the measured number; measured number outside the range, above it.
By their numbers in this assay, from the lowest: compounds 2, 1 and 3 (each within the scatter of the next); then compound 4.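

In this assay, the carbonyl carbon proves to be a position that responds to change: phenyl in place of pyrrolidin-1-yl gives a 2.8-fold higher number from compound 3 to compound 4 (0.44 log units; beyond the scatter), and phenyl in place of piperidin-1-yl gives a 2.9-fold higher number from compound 1 to compound 4 (0.47 log units; beyond the scatter). Both steps lie beyond the scatter, whereas exchanging one non-aromatic ring for the other gave only a 1.1-fold higher number from compound 1 to compound 3 (0.03 log units; within the scatter), which lies within it. Nothing measured here accounts for the longer half-life of compound 4.

The change replaces a non-aromatic ring with an aromatic one and also puts carbon instead of nitrogen on the carbonyl, so the compounds shown leave open which of the two goes with the step; a cyclohexyl group on the carbonyl carbon would separate them. Also open, from the compounds shown here alone, is whether a pyridyl ring or a fluorine on the new phenyl would keep the step.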